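The source may hold more compounds than are shown below. What is called first, only, known or untested is meant among the compounds shown, and "the series" means these compounds.

Measured compounds:
Compound 1, `C/C(=N\NC(=S)Nc1ccccc1[N+](=O)[O-])c1ccccn1`, gives 4.3 nM.
Compound 2, `C/C(=N/NC(=S)Nc1ccccc1F)c1ccccn1`, gives 5 nM.

Both compounds were tested in a functional assay on U-87MG ATCC cells (Homo sapiens) for cytotoxicity, read by MTT assay, with a stated time of 48 h; a lower number here means a stronger inhibitor, a higher number a weaker inhibitor. Among the two numbers, compound 1 has the smaller one, but compound 2 sits within the usual scatter of it, so the two cannot be told apart on these data alone. The step of interest leads from compound 1 to compound 3, `CC(=NNC(=S)Nc1ccccc1[N+](=O)[O-])c1ccccn1`, which has not yet been measured in this assay. The difference between the two is the two compounds have the same atoms and bonds; at least one stereo element is drawn with a configuration in one of them and without one in the other: 1 of 1 stereo elements differ; a double bond is drawn E in compound 1 and without a configuration in compound 3. For the measured compounds named here, since nothing leaves and nothing enters, and the only change lies in how the double bond is drawn, no step beyond the scatter is expected in this assay, in either direction. Compound 3 is therefore estimated at 4.3 nM, with a range from 2 nM to 9 nM. This estimate corresponds to an expected step of no change at the digits printed from compound 1 to compound 3 (within the scatter).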

Compound 3, half-maximal inhibitory concentration: 4.3 nM
Estimate against measurement, compound 3: no gap at the digits printed; the range from low to high includes it.
By their numbers in this assay, from the lowest: compounds 1, 3 and 2 (each within the scatter of the next).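

Compounds 1 and 2 differ in more than one place, so they gave no single change to read, and compound 1 with compound 3 now provides the first such step. In this assay, the double bond can go from drawn E to drawn without a configuration with no change at the digits printed from compound 1 to compound 3 (within the scatter), so removing the drawn configuration from this position leaves the number unmoved. The step concerns only how the structure is recorded, with no group lost or gained: the fact that one of compounds 1 and 3 is drawn with a defined configuration and the other without, at the place where they differ.

Because compound 3 names no configuration, the compounds shown do not tell whether the opposite configuration at this double bond, with the nitro group kept, would give a similar number. They also leave open what a methoxy group or an amine would give in the place of the nitro group.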